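A few compounds are considered here, and "the series" means these few. Any claim that something is new, unique, unknown or untested is made for them only; others in the source may bear on it.

In an ADME assay on microsomes from liver (Homo sapiens) for metabolic stability, read by LC-MS, tested at 1 uM (a lower number here means slower removal, a higher number faster removal of the compound), compound 1 `NC(=O)C1CCN(Cc2ccc([C@H]3CC[C@]4(CC3)OOC3(O4)C4CC5CC(C4)CC3C5)cc2)CC1` gives 10 mL.min-1.g-1 and compound 2 `CC(C)(O)CNCCCOc1ccc([C@H]2CC[C@]3(CC2)OOC2(O3)C3CC4CC(C3)CC2C4)cc1` gives 8 mL.min-1.g-1 and so stands level with compound 1 within the scatter. Compound 3 `NCCS(=O)(=O)CCOc1ccc([C@H]2CC[C@]3(CC2)OOC2(O3)C3CC4CC(C3)CC2C4)cc1` carries (2-aminoethyl)sulfonyl in place of ((2-hydroxy-2-methylpropyl)amino)methyl on a saturated chain carbon, two bonds along the chain from an oxygen on an aromatic ring, with (2-aminoethyl)sulfonyl in place of ((2-hydroxy-2-methylpropyl)amino)methyl on a saturated chain carbon, two bonds along the chain from an oxygen on an aromatic ring as the count of the difference. Within the data shown here, one measured step bears on this: a 1.3-fold lower number from compound 1 to compound 2 (0.10 log units; within the scatter) for an exchange of the whole group on the aromatic carbon, and it stays within the scatter. Among the measured compounds shown here, no measured compound holds a sulfonyl group, so this support is indirect. In this assay no step beyond the scatter is expected, and the estimate means a 1.1-fold lower number from compound 2 to compound 3 (0.06 log units; within the scatter) as an expected step of that small size. Compound 3 is estimated at 7 mL.min-1.g-1 with an expected range from 3 mL.min-1.g-1 to 18 mL.min-1.g-1 in this series.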

Compound 3, intrinsic clearance in microsomes: 9 mL.min-1.g-1
The estimate for compound 3 lay 1.3-fold (0.11 log units) below the measured number; the range from low to high includes it.
By their numbers in this assay, from the lowest: compounds 2, 3 and 1 (each within the scatter of the next).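

In this assay this position accepts a sulfonyl group in the chain: the step is a 1.1-fold higher number from compound 2 to compound 3 (0.05 log units; within the scatter) and the exchange of ((2-hydroxy-2-methylpropyl)amino)methyl for (2-aminoethyl)sulfonyl therefore leaves the number level. The whole-group exchange on the aromatic carbon reads the same way, with a 1.1-fold lower number from compound 1 to compound 3 (0.05 log units; within the scatter) for 2-((2-aminoethyl)sulfonyl)ethoxy in place of (4-carbamoylpiperidin-1-yl)methyl, so the three side chains shown do not separate in this read-out. Nothing measured explains why these different chains read alike.

The compounds shown leave open whether a carboxylic acid in place of the amine of the (2-aminoethyl)sulfonyl group, or a longer chain within that group, would stay level with these three. Going by these compounds, how a sulfonamide would read at the same place also remains open.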